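Halogen exchange on the shared core of compound 2

The source may report more compounds than this note shows. Statements on the series, on what has been measured and on what is new or still open speak of the compounds shown alone.

Measured compounds:
Compound 1 `CO[C@@H]1[C@H](N(C)c2ncc(-c3c[nH]c4ccc(F)cc34)s2)C[C@H]2O[C@]1(C)n1c3ccccc3c3c4c(c5c6cc(Cl)ccc6n2c5c31)C(=O)NC4`: 320 nM
Compound 2 `CO[C@@H]1[C@H](N(C)c2ncc(-c3c[nH]c4ccc(Br)cc34)s2)C[C@H]2O[C@]1(C)n1c3ccccc3c3c4c(c5c6cc(Cl)ccc6n2c5c31)C(=O)NC4`: 430 nM

In a functional assay on MV4-11 cells (Homo sapiens) for antiproliferative activity, read by CellTiter-Glo, with a stated time of 72 h (on this read-out higher numbers stand for weaker inhibition and lower numbers for stronger inhibition), compound 2 gives 430 nM, the higher of the two numbers recorded, with compound 1 nearby at 320 nM. Among the measured compounds shown here, the only measured step, a 1.3-fold higher number from compound 1 to compound 2 (0.13 log units; within the scatter), exchanged one halogen for another on the indole ring and stayed within the scatter. Compound 3 `CO[C@@H]1[C@H](N(C)c2ncc(-c3c[nH]c4ccc(Br)cc34)s2)C[C@H]2O[C@]1(C)n1c3ccccc3c3c4c(c5c6cc(Br)ccc6n2c5c31)C(=O)NC4` differs from compound 2 by bromo in place of chloro on an aromatic carbon. For the measured compounds named here, this halogen exchange sits on a different ring of the shared core than the step already measured, so that step bears on it only loosely; still, it is the sole guide available, and it suggests that one halogen replacing another changes this assay little. Compound 3 is therefore expected to stay close to compound 2, with no step beyond the scatter, and an estimated 1.0-fold higher number from compound 2 to compound 3 (0.02 log units; within the scatter) is expected. The estimate for compound 3 in this assay is 450 nM, expected to lie between 200 nM and 1000 nM.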

Compound 3, half-maximal inhibitory concentration: 390 nM
Compound 3: the middle estimate sits 1.2-fold (0.06 log units) above what was measured; low and high end bracket the measured number.
By their numbers in this assay, from the lowest: compounds 1, 3 and 2 (each within the scatter of the next).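

In this assay, bromo in place of chloro on an aromatic carbon gives a 1.1-fold lower number from compound 2 to compound 3 (0.04 log units; within the scatter) and so stays within the scatter. Among the compounds shown here, this extends what the earlier compounds showed, since their only step, a 1.3-fold higher number from compound 1 to compound 2 (0.13 log units; within the scatter), lay at another place on the shared core, whereas this one concerns the six-membered aromatic ring of carbon only, meta to a fused ring and para to a fused ring. Here the assay does not separate chloro from bromo, and no measurement on hand bears on what lies behind this result.

The compounds shown carry only a halogen at this place, so they leave open how the number would respond to a hydrogen, a methoxy group, a nitrile or an amine there. They also leave open whether fluoro would behave as chloro and bromo do at this place.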